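The source may report more compounds than this note shows. Statements on the series, on what has been measured and on what is new or still open speak of the compounds shown alone.

Measured so far in an ADME assay on BHK cells (Mesocricetus auratus) for cytotoxicity, read by MTT assay, with a stated time of 96 h; on this read-out higher numbers stand for lower toxicity in this test and lower numbers for higher toxicity in this test:
- compound 1 `COc1ccc(-c2nc3cc(C(F)(F)F)ccc3[nH]2)c(OC)c1OC`: 32000 nM
- compound 2 `COc1ccc(-c2nc3cc([N+](=O)[O-])ccc3[nH]2)c(OC)c1`: > 100000 nM

Only compound 1 has a measured number here. The entry of > 100000 nM for compound 2 is a limit of the assay and not a number. From the compounds shown here alone, compound 2 therefore stands at the limit of > 100000 nM in this assay, at which 1 of the 2 values shown sits, and how far its true value lies from that limit is unknown.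

Compound 3 `COc1ccc(-c2nc3cc([N+](=O)[O-])ccc3[nH]2)c(OC)c1OC` differs from compound 2 by methoxy in place of hydrogen on an aromatic carbon, ortho to two methoxy groups and meta to a large group: methoxy in place of hydrogen on an aromatic carbon. Among the compounds with values here, no measured pair shows this change on its own, so the expectation is tentative. It leans on compound 1, which bears a methoxy at that place and gives 32000 nM. A modest move toward lower numbers in this assay is expected, and compound 3 may well reach the limit again. The expected step is an at least 1.4-fold lower number from compound 2 to compound 3 (0.15 log units; that floor lies within the scatter). For compound 3 the estimated half-maximal cytotoxic concentration is 70000 nM, with an expected range of 25000 nM to 100000 nM.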

Compound 3, half-maximal cytotoxic concentration: > 100000 nM
Compound 3: no number, only a limit; the forecaster's own chance of this, stated with the estimate: 45%; middle value at least 1.4-fold (0.15 log units) from the limit.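

In this assay compound 3 gives > 100000 nM, which is a limit of the assay and not a number, so methoxy in place of hydrogen at this place does not bring the nitro compound down to a measured value. Compound 2 and compound 3 stand at the same limit, and the step between them for this change cannot be read: the limit of > 100000 nM in this assay, at which 2 of the 3 values shown sit.

Compound 1 and compound 3 carry the same methoxy groups and differ only in nitro in place of trifluoromethyl, and this change gives an at least 3.1-fold higher number from compound 1 to compound 3 (0.49 log units; beyond the scatter), so the measured value of compound 1 cannot be read as the work of the added methoxy alone.

From the compounds shown here alone, whether methoxy at this place moves the number at all remains open for the nitro compounds, and the same question stands for a core carrying trifluoromethyl. Going by these compounds, how an amine or a carboxylic acid in place of nitro would read in this assay also remains open.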